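The source may hold more compounds than are shown below. What is called first, only, known or untested is meant among the compounds shown, and "the series" means these compounds.

Measured so far in an ADME assay on HCT-116 cells (Homo sapiens) for cytotoxicity, read by CellTiter-Glo, with a stated time of 72 h; a lower number here means a stronger inhibitor, a higher number a weaker inhibitor:
Compound 1 `CC1CCN(C2CCN(S(=O)(=O)c3cn(C)c(=O)n(C)c3=O)CC2)CC1`: > 10000 nM, a limit of the assay
Compound 2 `Cc1cc(C)c(S(=O)(=O)N2CCC(N3CCC(c4ccccc4)CC3)CC2)c(C)c1`: > 5000 nM, a limit of the assay

Neither compound has yielded an actual number, so the two cannot be ranked against each other. Compound 2 stands at > 5000 nM, which is a limit and not a measured value.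

Compound 3 `C#CCCC(=O)CC1CCN(C2CCN(S(=O)(=O)c3c(C)cc(C)cc3C)CC2)CC1` keeps the core of compound 2 and changes one group. It has ((but-3-yn-1-yl)carbonyl)methyl in place of phenyl on a saturated ring carbon of a six-membered non-aromatic ring with 1 nitrogen: ((but-3-yn-1-yl)carbonyl)methyl in place of phenyl on a saturated ring carbon.

For the measured compounds named here, no measured pair shows directly what a change at this place does in this assay. Compound 1 also lacks a phenyl at this place and gives > 10000 nM, again a limit. No change beyond the usual scatter is therefore expected, and another limit is the likeliest result. The expected change is a step that the limit leaves unreadable from compound 2 to compound 3. For compound 3 the estimated value is 8000 nM, with an expected range of 3000 nM to 20000 nM.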

Compound 3, half-maximal inhibitory concentration: > 5000 nM
Compound 3: a limit, no number (the forecaster's own chance of this, stated with the estimate: 75%); the middle value is on the limit's open side.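

No step can be read from compound 2 to compound 3, because each gives only a limit of the assay and not a number: the limit of > 5000 nM in this assay, at which 2 of the 3 values shown sit.

The compounds shown leave open whether phenyl or ((but-3-yn-1-yl)carbonyl)methyl at this place makes any difference in this assay, and at what concentration any of these compounds would reach half-maximal inhibition.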